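Sulfonamide series: the step from compound 3 to compound 4

The compounds below may be only part of what the source reports. "The series", "measured", "known", "first", "only" and "open" are said of these compounds alone.

Measured in a functional assay on HT-29 cells (Homo sapiens) for antiproliferative activity, read by sulforhodamine B assay, with a stated time of 48 h; a lower number here means a stronger inhibitor, a higher number a weaker inhibitor:
- compound 1 `O=C1NCCN1c1ccc(S(=O)(=O)Nc2ccc(Cl)cc2)cc1`: 220 nM
- compound 2 `O=C1NCCN1c1ccc(S(=O)(=O)Nc2ccc(Br)cc2)cc1`: 300 nM
- compound 3 `O=C1NCCN1c1ccc(S(=O)(=O)Nc2cccc(Cl)c2)cc1`: 55 nM

Compound 3 has the lowest number of the three. The two steps leading to it lie beyond the scatter: a 4.0-fold lower number from compound 1 to compound 3 (0.60 log units; beyond the scatter) and a 5.5-fold lower number from compound 2 to compound 3 (0.74 log units; beyond the scatter). The remaining step stays within the scatter: a 1.4-fold higher number from compound 1 to compound 2 (0.13 log units; within the scatter).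

The next compound is compound 4 `COc1ccccc1NS(=O)(=O)c1ccc(N2CCNC2=O)cc1`, with 2-methoxyphenyl in place of 3-chlorophenyl on a sulfonamide nitrogen. Going by the values given here, no measured compound carries a 2-methoxyphenyl group, so the evidence is indirect. The closest guides are the two modest steps that reach compound 3 through changes of the group on the sulfonamide nitrogen. Leaving the 3-chlorophenyl group has so far meant a higher number, though only two other groups have been measured. A modest step of similar size toward a higher number is therefore expected in this assay, with wide uncertainty. The expected step is a 3.6-fold higher number from compound 3 to compound 4 (0.56 log units; beyond the scatter). The estimate for compound 4 is 200 nM, within an expected range of 40 nM to 900 nM.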

Compound 4, half-maximal inhibitory concentration: 550 nM
Estimate against measurement, compound 4: 2.8-fold (0.44 log units) below, and the stated range covers the measured number.
By their numbers in this assay, from the lowest: compound 3; then compounds 1, 2 and 4 (each within the scatter of the next, the first and the last beyond it).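

In this assay, a third kind of group on the sulfonamide nitrogen also falls short of the 3-chlorophenyl group, with a 10-fold higher number from compound 3 to compound 4 (1.00 log units; beyond the scatter) and no listed compound going against this. The 2-methoxyphenyl group brings oxygen and a hydrogen-bond acceptor in place of chlorine, yet the series gains no lower number from it: the comparison gives a 2.5-fold higher number from compound 1 to compound 4 (0.40 log units; beyond the scatter) and also a 1.8-fold higher number from compound 2 to compound 4 (0.26 log units; within the scatter). No measurement here explains these steps.

The compounds shown do not separate the effect of the methoxy group from that of its ring position, which a 3-methoxyphenyl or 2-chlorophenyl group on the same nitrogen would address. Also open, on these data alone, is how an aminophenyl or carboxyphenyl group would read at this position, and whether the 3-chlorophenyl advantage holds beyond these four compounds.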